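The source may report more compounds than this note shows. Statements on the series, on what has been measured and on what is new or still open speak of the compounds shown alone.

Working notes on the series in a functional assay on the whole organism (strain Swiss) with Mus musculus as the target, in the maximal electroshock model, with a stated time of 0.25 h, at a dose of 100 mg/kg by the intraperitoneal route; a higher number here means a stronger effect of the compound at the dose given, a lower number a weaker effect. Compound 1 `COCC(C(=O)N1CCN(c2cccc(C(F)(F)F)c2)CC1)N1C(=O)CCC1=O` gives 100%. Compound 2 `CC(C(=O)N1CCN(c2ccccc2F)CC1)N1C(=O)CCC1=O` gives 75%, and compound 3 `CCC(C(=O)N1CCN(c2ccccc2F)CC1)N1C(=O)CCC1=O` gives 0%. Compound 3 thus stands lowest of the three numbers; compound 2 lies nearest to it and compound 1 furthest, and both gaps are beyond the scatter. Within the data shown here, the one step that changes a single place is a number 75 percentage points lower from compound 2 to compound 3 (beyond the scatter), a methyl in place of hydrogen on a saturated chain carbon, two bonds along the chain from an amide-type nitrogen in a ring and a carbonyl carbon; this single change removes the effect entirely.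

Compound 4 `CCC(C(=O)N1CCN(c2cccc(Cl)c2)CC1)N1C(=O)CCC1=O` is not yet measured. It differs from compound 3 in one place: 3-chlorophenyl in place of 2-fluorophenyl on an amine nitrogen in a ring. Among the measured compounds shown here, no measured pair in this set changes only the group on the amine nitrogen in the ring, so no step bears directly on this change; compound 1 and compound 2 differ in more than one place, and their values show only that both were active. Compound 4 keeps the same saturated chain as compound 3. The step of a number 20 percentage points higher from compound 3 to compound 4 (beyond the scatter) is therefore expected to be small and upward, if anything. For compound 4 the estimate is 20%, with an expected range from 0% to 60%.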

Compound 4, a percentage reported as activity, at one dose (the size of the read-out at that dose, not a potency): 50%
The estimate for compound 4 lay 30 percentage points below the measured number; low and high end bracket the measured number.
By their numbers in this assay, from the lowest: compound 3; then compound 4; then compound 2; then compound 1.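

In this assay, the group on the amine nitrogen in the ring proves able to change the read-out on its own: with the saturated chain held constant, 3-chlorophenyl in place of 2-fluorophenyl gives a number 50 percentage points higher from compound 3 to compound 4 (beyond the scatter). The chain of compound 3 therefore does not by itself abolish the effect, since compound 4 carries the same chain and gives 50%, so the loss seen in a number 75 percentage points lower from compound 2 to compound 3 (beyond the scatter) belongs, as far as the data go, to a compound with the 2-fluorophenyl group. Nothing available explains why this exchange of aryl groups restores the effect, and as a read-out at one dose the number says nothing about potency.

The exchange alters both the halogen and its place on the aromatic ring, so 3-fluorophenyl and 2-chlorophenyl analogues on the same chain would be needed to separate the two. Also open, on these data alone, is whether the 3-chlorophenyl group changes the number in the same direction on the chain of compound 2, and whether an unsubstituted phenyl retains any of the effect.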